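From phenyl to benzyl at a chain end

The source may report more compounds than this note shows. Statements on the series, on what has been measured and on what is new or still open speak of the compounds shown alone.

Measured in a functional assay on NCI-H630 cells (Homo sapiens) for cytotoxicity, read by sulforhodamine B assay, with a stated time of 5 days; on this read-out lower numbers stand for stronger inhibition and higher numbers for weaker inhibition:
- Compound 1 (`O=C(CCCCCCCCCCc1ccccc1)N[C@H]1CCOC1=O`) gives (70000 nM)
- Compound 2 (`O=C(CCCCCCCCc1ccccc1)N[C@H]1CCOC1=O`) gives a limit (> 100000 nM)

Compound 2 gives a limit of the assay and not a number (> 100000 nM), the only such case here (the limit of > 100000 nM in this assay, at which 1 of the 2 values shown sits). Compound 3 (`O=C(CCCCCCCCCc1ccccc1)N[C@H]1CCOC1=O`) carries benzyl in place of phenyl on a saturated chain carbon, eight bonds along the chain from a carbonyl carbon. The same difference, cut one bond further out, reads benzyl to phenethyl. Among the compounds with values here, one measured step bears on this, the swap of phenethyl for phenyl at that place (an at least 1.4-fold higher number from compound 1 to compound 2 (0.15 log units; that floor lies within the scatter)). Moving from phenyl to benzyl retraces part of that small step in reverse, so no change beyond the scatter is expected in this assay, and any shift should lean towards a lower number. The expected change is small (an at least 1.1-fold lower number from compound 2 to compound 3 (0.04 log units; that floor lies within the scatter)). For compound 3 the estimated value is 90000 nM (expected range 50000 nM to 150000 nM).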

Compound 3, half-maximal inhibitory concentration: > 100000 nM
Compound 3 ended at the assay's limit; the forecaster's own chance of this, stated with the estimate: 45%; middle value at least 1.1-fold (0.04 log units) from the limit.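

In this assay compound 3 gives a limit of the assay and not a number, > 100000 nM. The step between compound 2 and compound 3 cannot be read, so nothing can be said about how benzyl compares with phenyl at this place on the saturated chain. The only readable step is an at least 1.4-fold higher number from compound 1 to compound 3 (0.15 log units; that floor lies within the scatter), so neither shorter chain end is shown to differ from the phenethyl end of compound 1 by more than the scatter, and the limit now holds more of the set: the limit of > 100000 nM in this assay, at which 2 of the 3 values shown sit.

Going by these compounds, how steeply the read-out depends on the chain end remains open, as only compound 1 gives an actual number. An amine or a carboxylic acid at the chain end, or a chain longer than that of compound 1, would show whether this place can give a clearly lower number.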